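A few compounds are considered here, and "the series" means these few. Any claim that something is new, unique, unknown or untested is made for them only; others in the source may bear on it.

Working notes on the series.

Three compounds have numbers in an assay on CHO cells for agonist activity at Free fatty acid receptor 1 (Homo sapiens), read by luminescence, with a stated time of 20 s, in the presence of a further agent that is not named here; a higher number here means that more compound is needed for the effect, a lower number that less compound is needed. Compound 1 `Cc1cc(Cl)ccc1-c1cc(COc2ccc([C@H](CC(=O)O)c3nccn3C)cc2)ccc1C` gives 9800 nM; compound 3 `Cc1cc(Cl)ccc1-c1cccc(COc2ccc([C@H](CC(=O)O)c3nccn3C)cc2)c1C` gives 23000 nM; compound 2 `Cc1ccccc1-c1cccc(COc2ccc([C@H](CC(=O)O)c3nccn3C)cc2)c1` gives 89000 nM. On these numbers compound 2 stands highest of the three: its nearest neighbour is compound 3, which lies beyond the scatter below it, and compound 1 lies further still, also beyond the scatter. Among the compounds with values here, compound 2 is thus the least potent of the measured set, and no single-point step between any two of the measured compounds is available for comparison.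

The next compound, compound 4 `Cn1ccnc1[C@@H](CC(=O)O)c1ccc(OCc2cccc(-c3ccccc3Cl)c2)cc1`, differs from compound 2 in one place: chloro in place of methyl on an aromatic carbon. Cut one bond further out, the same difference reads 2-methylphenyl to 2-chlorophenyl.

Within the data shown here, no measured pair shows what this change does here, so the expectation rests on the position of compound 2 alone. A step from compound 2 to compound 4 of a 1.5-fold lower number from compound 2 to compound 4 (0.17 log units; within the scatter) is expected, which is within the usual scatter, with no firm direction. Compound 4 is therefore estimated at 60000 nM in this assay, with a range from 20000 nM to 180000 nM.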

Compound 4, half-maximal effective concentration: 56000 nM
Compound 4: middle estimate off by 1.1-fold (0.03 log units), on the high side; measured number inside the range.
By their numbers in this assay, from the lowest: compound 1; then compound 3; then compounds 4 and 2 (each within the scatter of the next).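

Within the data shown here, the step of a 1.6-fold lower number from compound 2 to compound 4 (0.20 log units; within the scatter) is the first one that changes a single place, so this assay can now be read for one substituent on its own. At this aromatic carbon, ortho to a large group, chloro in place of methyl gives no change that stands clear of the scatter, and the 2-chlorophenyl and 2-methylphenyl compounds cannot be told apart on these numbers. This holds for this one pair only and says nothing yet about the same change on the core of compound 1 or compound 3. No supporting measurement bears on this result, so the step stands as an observation without an explanation.

On these data alone, what remains open is whether this place tolerates only groups of the size of methyl and chloro, or whether a methoxy group, a trifluoromethyl group or an amine would move the number beyond the scatter. Among these compounds, also open is how much the further substituents of compound 1 and compound 3 each contribute, since no single-place step links either of them to compound 2 or compound 4.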